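Swapping Chloro for Trifluoromethyl on a Weak Sulfonamide

The source may report more compounds than this note shows. Statements on the series, on what has been measured and on what is new or still open speak of the compounds shown alone.

Compound 1 `O=S(=O)(Nc1ccc(-c2nc3ccccc3o2)cc1)c1ccccc1Cl` was tested in an assay on cells for inhibition of HSP60/HSP10 (Homo sapiens), with a stated time of 60 min; on this read-out higher numbers stand for weaker inhibition and lower numbers for stronger inhibition. For compound 1 this assay reports only a limit, > 100000 nM, and no number. Two close relatives were measured as well. Compound 2 `O=S(=O)(Nc1ccc(-c2nc3ccccc3o2)cc1)c1cccc(Cl)c1` gives 54000 nM in this assay, and compound 3 `O=S(=O)(Nc1ccc(-c2nc3ccccc3o2)cc1)c1ccc(F)cc1` gives 73000 nM. From the compounds shown here alone, the steps from compound 1 are an at least 1.8-fold lower number from compound 1 to compound 2 (0.26 log units; that floor lies within the scatter) and an at least 1.3-fold lower number from compound 1 to compound 3 (0.13 log units; that floor lies within the scatter); both start from the limit (the limit of > 100000 nM in this assay, at which 1 of the 3 values shown sits), so their true size stays open. Between the two measured relatives the step is a 1.4-fold higher number from compound 2 to compound 3 (0.13 log units; within the scatter).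

Compound 4 `O=S(=O)(Nc1ccc(-c2nc3ccccc3o2)cc1)c1ccccc1C(F)(F)F` is the next compound to be measured. It differs from compound 1 in one place: trifluoromethyl in place of chloro on an aromatic carbon. Among the compounds with values here, none of the measured steps changes this same group, so they give only the surroundings: every relative so far is a weak inhibitor, and the changes away from compound 1 gave no step clearly beyond the scatter. Compound 4 is therefore expected to remain weak, with an estimated step of a number no higher from compound 1 to compound 4 (the limit leaves the size open). The estimate for compound 4 in this assay is 100000 nM, with a range from 40000 nM to 300000 nM.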

Compound 4, half-maximal inhibitory concentration: 74000 nM
For compound 4 the middle estimate is 1.4-fold (0.13 log units) above the measured one, and the stated range covers the measured number.
By their numbers in this assay, from the lowest: compounds 2, 3 and 4 (each within the scatter of the next). At a limit, above all of these: compound 1.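

Trifluoromethyl on this aromatic carbon, ortho to a large group, gives a measurable number in this assay, which chloro at the same place in compound 1 does not. The step is an at least 1.3-fold lower number from compound 1 to compound 4 (0.13 log units; that floor lies within the scatter), and it can be read only as a floor, so the change may be small or much larger: the limit of > 100000 nM in this assay, at which 1 of the 4 values shown sits. Even so, this position holds the bigger group, with its four heavy atoms in place of one, and compound 4 stays a weak inhibitor, so this swap brings no step shown to lie beyond the scatter.

From the compounds shown here alone, whether a different kind of group at this position, such as an amine or a carboxylic acid, would shift the number clearly remains open. Going by these compounds, it is also open how the same swap would behave on another ring position.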